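Compound 2 to compound 4: hydrogen in place of amino

A few compounds are considered here, and "the series" means these few. Any claim that something is new, unique, unknown or untested is made for them only; others in the source may bear on it.

In an ADME assay on H9 cells (Homo sapiens) for cytotoxicity, read by XTT assay, with a stated time of 6 days (on this read-out higher numbers stand for lower toxicity in this test and lower numbers for higher toxicity in this test), compound 1 (`Cc1cc(Br)cc(C)c1Oc1cc(Nc2ccc(C#N)cc2)c(N)cc1N`) gives 38400 nM, and compound 2 (`Cc1cc(C#N)cc(C)c1Oc1cc(Nc2ccc(C#N)cc2)c(N)cc1N`) gives 51000 nM. Compound 3 (`Cc1cc(Br)cc(C)c1Oc1cc(Nc2ccc(C#N)cc2)c(N)cc1[N+](=O)[O-]`) gives 45500 nM; 36400 nM (2 entries), and the several entries of compound 3 in this assay, 45500 nM; 36400 nM (2 entries) offer a direct view of how far repeats of a single compound lie apart. Compound 2 stands level with the other two, within the scatter of compound 1 and of both entries for compound 3.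

The next compound is compound 4 (`Cc1cc(C#N)cc(C)c1Oc1ccc(N)c(Nc2ccc(C#N)cc2)c1`), which differs from compound 2 by hydrogen in place of amino on an aromatic carbon, para to a (4-cyanophenyl)amino group.

Among the compounds with values here, no measured step covers this change. Within the data shown here, the only measured step, a 1.3-fold higher number from compound 1 to compound 2 (0.12 log units; within the scatter), is cyano in place of bromo at another site and stays within the scatter. The values of compound 1 and compound 3 also lie within the scatter of each other. From the compounds shown here alone, these three compounds therefore give no sign of a large move in this assay, although the loss of this amino group itself is untested, so the range stays wide.

No shift beyond the scatter is expected, and the estimated step is a 1.3-fold lower number from compound 2 to compound 4 (0.11 log units; within the scatter). The expected value for compound 4 is 40000 nM, with an estimated range from 15000 nM to 100000 nM.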

Compound 4, half-maximal cytotoxic concentration: 49800 nM
Estimate against measurement, compound 4: 1.2-fold (0.10 log units) below, and the stated range covers the measured number.
By their numbers in this assay, from the lowest: compounds 1, 4 and 2 (each within the scatter of the next).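

In this assay, hydrogen in place of amino on this aromatic carbon, ortho to a large group and para to a (4-cyanophenyl)amino group, gives a 1.0-fold lower number from compound 2 to compound 4 (0.01 log units; within the scatter). Within the data shown here, the only earlier step changed a different site, so this is the first reading of a change at this carbon, and the amino group there proves dispensable for the level of this read-out in the cyano compounds. A step this small cannot be told apart from the distance between repeats of a single compound: the several entries of compound 3 in this assay, 45500 nM; 36400 nM (2 entries)

From the compounds shown here alone, the same carbon carries a nitro group in compound 3, but that compound has bromo rather than cyano, so hydrogen at this carbon remains unread alongside bromo, and it is open whether the flat result holds there. Going by these compounds, whether any group at this carbon moves the number beyond the scatter also stays open, for example a methoxy group, a carboxylic acid or a longer chain such as an aminoethyl group, and so does the effect of removing the other amino group, the one meta to this carbon.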